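Series notes: cyano in place of fluoro

The compounds below may be only part of what the source reports. "The series", "measured", "known", "first", "only" and "open" are said of these compounds alone.

Measured so far:
- compound 1 `COc1ccc(-c2nc3c(c(C)nn3-c3ccccc3)c(-c3ccccc3O)c2C#N)cc1` gives > 23000 nM (a limit)
- compound 2 `CCCc1ccc(-c2nc3c(c(C)nn3-c3ccccc3)c(-c3ccccc3O)c2C#N)cc1` gives 22500 nM
- compound 3 `Cc1nn(-c2ccccc2)c2nc(-c3ccc(F)cc3)c(C#N)c(-c3ccccc3O)c12` gives > 20000 nM (a limit)

In an ADME assay on BJ cells (Homo sapiens) for cytotoxicity, with a stated time of 72 h (on this read-out lower numbers stand for an effect already at smaller amounts and higher numbers for an effect only at larger amounts of compound), compound 3 stands at > 20000 nM as a limit of the assay, not a number.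

Compound 4 `Cc1nn(-c2ccccc2)c2nc(-c3ccc(C#N)cc3)c(C#N)c(-c3ccccc3O)c12` differs from compound 3 by cyano in place of fluoro on an aromatic carbon (cyano in place of fluoro on an aromatic carbon, para to a large group, 4-fluorophenyl to 4-cyanophenyl).

Three measured changes at this same aromatic carbon bear on the step. They give an at least 1.0-fold lower number from compound 1 to compound 2 (0.00 log units; that floor lies within the scatter) and a step that the two limits leave unreadable from compound 1 to compound 3 and a step that the limit leaves unreadable from compound 2 to compound 3 with no size readable beyond the scatter. For the measured compounds named here, compound 2 at 22500 nM is the only number in the set.

No step beyond the scatter is therefore expected, and no direction. The expected step is a number no higher from compound 3 to compound 4 (the limit leaves the size open) in this estimate. Another limit instead of a number is also quite likely.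

In this assay the estimated value for compound 4 is 20000 nM and is expected to fall from 11000 nM to 32000 nM in the assay.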

Compound 4, half-maximal effective concentration: > 20000 nM
Compound 4: only a limit was reported; the forecaster's own chance of this, stated with the estimate: 60%; the middle value sits exactly at the limit.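

In this assay compound 4 gives > 20000 nM, a limit of the assay and not a number. For the compounds shown here, no step from compound 1, compound 2 or compound 3 to compound 4 can be read. The compounds shown leave open whether cyano in place of fluoro changes this read-out at all.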